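This account rests on a few compounds, and the source may have more. Where it says the series, first, only, none or still open, it means among the compounds named here.

Series notes. In an ADME assay on L02 cells (Homo sapiens) for antiproliferative activity, read by MTT assay, with a stated time of 48 h (a higher number here means a weaker inhibitor, a lower number a stronger inhibitor), compound 1 (`Cc1ccc(-n2nncc2CN2C(=O)C3(C(C#N)=C(N)Oc4c(N)cc5nc6ccccc6nc5c43)c3ccccc32)cc1C`) gives > 50000 nM, a limit of the assay rather than a number. Compound 2 (`Cc1ccc(Cl)cc1-n1nncc1CN1C(=O)C2(C(C#N)=C(N)Oc3c(N)cc4nc5ccccc5nc4c32)c2ccccc21`) likewise gives > 50000 nM, again a limit and not a number. The only measured step, a step that the two limits leave unreadable from compound 1 to compound 2, is therefore of unreadable size, and on the numbers shown compound 2 stands only as a limit; both values sit at the limit of > 50000 nM in this assay, at which 2 of the 2 values shown sit. Compound 3 (`COc1cc(-n2nncc2CN2C(=O)C3(C(C#N)=C(N)Oc4c(N)cc5nc6ccccc6nc5c43)c3ccccc32)c(OC)cc1Cl`) is the next member, and the change is 4-chloro-2,5-dimethoxyphenyl in place of 5-chloro-2-methylphenyl on an aromatic nitrogen. Going by the values given here, no measured step bears readably on this change, so neither a direction nor a size can be drawn from the two limits. The step is expected to be none beyond the scatter, a step that the limit leaves unreadable from compound 2 to compound 3, with compound 3 most likely reporting a limit once more in this assay. Compound 3 is accordingly estimated at 80000 nM, with a range from 30000 nM to 300000 nM.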

Compound 3, half-maximal inhibitory concentration: > 50000 nM
Compound 3 was reported as a limit; the forecaster's own chance of this, stated with the estimate: 85%; the middle value does not contradict the limit.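

Compound 3 also reports a limit and not a number in this assay, so neither step into compound 3, from compound 1 or from compound 2, can be read: the limit of > 50000 nM in this assay, at which 3 of the 3 values shown sit. The compounds shown leave open whether any change of the substituted phenyl group on the aromatic nitrogen moves the read-out in this assay at all.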